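Adding chlorines to the aryl ether of a diamino-triazine spirocycle

The source may hold more compounds than are shown below. What is called first, only, known or untested is meant among the compounds shown, and "the series" means these compounds.

Going by the values given here, compound 2 `NC1=NC2(CCOCC2)N(OCCCOc2ccc(Cl)cc2)C(N)=N1` gives 690 nM in a functional assay on HCT-116 cells (Homo sapiens) for antiproliferative activity, read by MTT assay, with a stated time of 72 h (a higher number here means a weaker inhibitor, a lower number a stronger inhibitor), and stands highest of the two numbers seen; compound 1 `NC1=NC2(CCSCC2)N(OCCCOc2ccc(Cl)c(Cl)c2)C(N)=N1` gives 1 nM, but the two differ in two places, so no single step is drawn. Compound 3 `NC1=NC2(CCOCC2)N(OCCCOc2cc(Cl)c(Cl)cc2Cl)C(N)=N1` is the one to be measured, differing from compound 2 by 2,4,5-trichlorophenyl in place of 4-chlorophenyl on an oxygen on a saturated carbon. Among the compounds with values here, with no comparable step recorded, a moderate downward shift from compound 2 to compound 3 is expected, a 4.6-fold lower number from compound 2 to compound 3 (0.66 log units; beyond the scatter), beyond the scatter but uncertain. Compound 3 is estimated at 150 nM, within 20 nM to 1500 nM.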

Compound 3, half-maximal inhibitory concentration: 2750 nM
Compound 3: middle estimate off by 18-fold (1.26 log units), on the low side, and the stated range ends below it.
By their numbers in this assay, from the lowest: compound 1; then compound 2; then compound 3.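

On the oxygen on a saturated carbon, 2,4,5-trichlorophenyl in place of 4-chlorophenyl gives a 4.0-fold higher number from compound 2 to compound 3 (0.60 log units; beyond the scatter) in this assay as the only single-place comparison shown. At this position, then, the larger chlorine count goes with a weaker result, not a stronger one. Nothing available gives a reason for this step. On these data alone, what stays open is whether a methoxy group or a nitrile in place of these chlorines would lower the number on the core shared by compound 2 and compound 3.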